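This account rests on a few compounds, and the source may have more. Where it says the series, first, only, none or still open, it means among the compounds named here.

Compound 1 `N#Cc1ccc(-c2cccc(CO[C@@H]3COc4nc([N+](=O)[O-])cn4C3)c2)cc1` and compound 2 `O=[N+]([O-])c1cn2c(n1)OC[C@@H](OCc1cccc(-c3ccc(F)cc3)c1)C2` share one core and differ in a single spot: fluoro in place of cyano on an aromatic carbon. In an ADME assay on Vero cells (Chlorocebus sabaeus) for cytotoxicity, with a stated time of 72 h (a lower number here means a stronger inhibitor, a higher number a weaker inhibitor), compound 1 gives > 128000 nM, which is a limit of the assay rather than a number. Compound 2 gives > 128000 nM, also a limit. Between them stands a step that the two limits leave unreadable from compound 1 to compound 2. Compound 3 `N#Cc1ccc(-c2ccc(CO[C@@H]3COc4nc([N+](=O)[O-])cn4C3)s2)cc1` carries another core; how that core differs from the core of compound 1 is not broken down here. In this assay compound 3 gives > 128000 nM, again a limit. Across these three compounds (the limit of > 128000 nM in this assay, at which 3 of the 3 values shown sit). Compound 4 `O=[N+]([O-])c1cn2c(n1)OC[C@@H](OCc1ccc(-c3ccc(F)cc3)s1)C2` is compound 3 with the same change: fluoro in place of cyano on an aromatic carbon. The expected step is a step that the limit leaves unreadable from compound 3 to compound 4, because a step that the two limits leave unreadable from compound 1 to compound 2 gave no readable size. Compound 4 is therefore estimated at 200000 nM, most likely reported as a limit once more.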

Compound 4, half-maximal inhibitory concentration: > 128000 nM
Compound 4: only a limit was reported (the forecaster's own chance of this, stated with the estimate: 90%); the middle value lies beyond the limit too.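

No step can be read from compound 3 to compound 4, because both values are limits, not numbers: the limit of > 128000 nM in this assay, at which 4 of the 4 values shown sit.

The compounds shown leave open whether fluoro in place of cyano changes cytotoxicity at all in this assay, and at what concentration any of them would reach half-maximal inhibition.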